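This account rests on a few compounds, and the source may have more. Where it says the series, first, only, none or still open, it means among the compounds named here.

Working notes on the series, step from compound 3 to compound 4.

Compound 3 `N#Cc1ccc(-c2nc(N)c3cc(CN4CCC(F)CC4)sc3n2)cc1` gives 8430 nM in an assay on CHO-K1 cells for antagonist activity at adenosine receptor A1 (Homo sapiens), read by a beta-galactosidase reporter, with stated times of 15 min and 6 h (on this read-out higher numbers stand for weaker inhibition and lower numbers for stronger inhibition), the highest number among the three measured compounds. Compound 1 `Nc1nc(-c2ncco2)nc2sc(CN3CC=CC3)cc12` gives 3890 nM in this assay, and compound 2 `N#Cc1cccc(-c2nc(N)c3cc(CN4CC=CC4)sc3n2)c1` gives 2070 nM. Going by the values given here, the one single-point step measured so far, a 1.9-fold lower number from compound 1 to compound 2 (0.27 log units; within the scatter), concerns the aromatic substituent and not the amine.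

Compound 4 `N#Cc1ccc(-c2nc(N)c3cc(CN4CC=CC4)sc3n2)cc1` differs from compound 3 by a group of 5 heavy atoms (4 carbon, 1 nitrogen; one five-membered non-aromatic ring with 1 hetero atom) in place of a group of 7 heavy atoms (5 carbon, 1 nitrogen, 1 fluorine; one six-membered non-aromatic ring with 1 hetero atom), on a saturated chain carbon bound to an aromatic carbon. Among the compounds with values here, no measured step isolates this change: compound 3 differs from compound 1 and compound 2 at the amine and at the aromatic substituent together, so the lower numbers of those two compounds cannot be assigned to either change alone. What can be said is that both measured compounds bearing the entering group return lower numbers than compound 3.

The expected step is therefore a moderate lowering of the number, a 2.4-fold lower number from compound 3 to compound 4 (0.38 log units; beyond the scatter), with wide uncertainty. Compound 4 is estimated at 3500 nM in this assay, within a range of 1200 nM to 10000 nM.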

Compound 4, inhibition constant: 2350 nM
Estimate against measurement, compound 4: 1.5-fold (0.17 log units) above; the range from low to high includes it.
By their numbers in this assay, from the lowest: compounds 2, 4 and 1 (each within the scatter of the next); then compound 3.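

In this assay, going by these compounds alone, the exchange on a saturated chain carbon bound to an aromatic carbon is now isolated: the five-membered ring group in place of 4-fluoropiperidin-1-yl gives a 3.6-fold lower number from compound 3 to compound 4 (0.55 log units; beyond the scatter), a reading the earlier compounds could not give, since they differed from compound 3 in two places. With that five-membered ring group held constant, 4-cyanophenyl in place of 3-cyanophenyl gives a 1.1-fold higher number from compound 2 to compound 4 (0.06 log units; within the scatter), and 4-cyanophenyl in place of 1,3-oxazol-2-yl gives a 1.7-fold lower number from compound 1 to compound 4 (0.22 log units; within the scatter), so these three aromatic groups are not separated here. Nothing available gives a cause for the step at the chain carbon.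

That step changes ring size, the fluorine and the double bond together, and the compounds shown do not separate them. As far as these compounds go, how a morpholin-4-yl group on the same chain carbon would compare remains open.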